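Shifting the nitro group: from compound 2 to compound 3

A few compounds are considered here, and "the series" means these few. Any claim that something is new, unique, unknown or untested is made for them only; others in the source may bear on it.

compound 1 `Clc1cccc(CSc2nnc(-c3ccncc3)n2-c2ccccc2)c1` — 9820 nM
compound 2 `O=[N+]([O-])c1ccccc1CSc1nnc(-c2ccncc2)n1-c1ccccc1` — a limit only, > 50000 nM

In a functional assay on HCT-116 cells (Homo sapiens) for inhibition, read by MTT assay, with a stated time of 48 h (a higher number here means a weaker inhibitor, a lower number a stronger inhibitor), compound 1 gives 9820 nM. Compound 2 stands at the limit of > 50000 nM in this assay, at which 1 of the 2 values shown sits, so its value is a limit and not a number. Within the data shown here, the one measured step, an at least 5.0-fold higher number from compound 1 to compound 2 (0.70 log units; beyond the scatter), shows an at least modest weakening. Compound 3 `O=[N+]([O-])c1cccc(CSc2nnc(-c3ccncc3)n2-c2ccccc2)c1` differs from compound 2 by 3-nitrophenyl in place of 2-nitrophenyl on a saturated chain carbon bound to a sulfur; its nitrophenyl thus carries the substituent where compound 1 carries chlorine. Among the measured compounds shown here, that step offers the only guide, and a return toward compound 1 is expected but uncertain. For compound 3 the estimate is 30000 nM, range 8000 nM to 100000 nM, an expected step of an at least 1.6-fold lower number from compound 2 to compound 3 (0.22 log units; that floor lies within the scatter).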

Compound 3, half-maximal inhibitory concentration: 19800 nM
For compound 3 the middle estimate is 1.5-fold (0.18 log units) above the measured one; the measured number falls inside the stated range.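

On the saturated chain carbon bound to a sulfur, 3-nitrophenyl in place of 2-nitrophenyl gives an at least 2.5-fold lower number from compound 2 to compound 3 (0.40 log units; beyond the scatter), so with the same atoms, the placement of the nitro group alone changes the result. The value of compound 2 is a limit, not a number: the limit of > 50000 nM in this assay, at which 1 of the 3 values shown sits.

Nitro in place of chloro on an aromatic carbon gives a 2.0-fold higher number from compound 1 to compound 3 (0.30 log units; within the scatter), so the two substituents cannot be told apart at this placement.

Open, from the compounds shown here alone, is whether an amine or a carboxylic acid on this phenyl would hold this level, and whether a longer chain between the sulfur and the phenyl would shift it.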